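The source may hold more compounds than are shown below. What is called first, only, known or untested is meant among the compounds shown, and "the series" means these compounds.

Going by the values given here, compound 1 `O=C(CBr)Nc1ccc(C(=O)/C=C/c2ccc(Cl)cc2)cc1` gives 54% in a functional assay on the whole organism (strain albino) for inhibition, with Rattus norvegicus as the target, read by paw edema, with stated times of 30 min and 5 h, at a dose of 100 mg/kg by the oral route (a lower number here means less inhibition, a higher number more inhibition at the dose given (going by the name of the read-out)), the higher of the two numbers so far. Compound 2 `COc1ccc(/C=C/C(=O)c2ccc(NC(=O)CBr)cc2)cc1`, carrying methoxy in place of chloro on an aromatic carbon, gives 34%, a step of a number 20 percentage points lower from compound 1 to compound 2 (beyond the scatter). Compound 3 `CC(Br)C(=O)Nc1ccc(C(=O)/C=C/c2ccc(Cl)cc2)cc1` differs from compound 1 elsewhere: methyl in place of hydrogen on a saturated chain carbon bound to a bromine atom and a carbonyl carbon. Among the compounds with values here, no measured step touches the saturated chain carbon bound to a bromine atom and a carbonyl carbon, so the one known step offers no direct guide. Compound 3 is therefore expected to stay near compound 1, with a step of no change at the digits printed from compound 1 to compound 3 (within the scatter), within the scatter. Compound 3 is estimated at 54%, between 35% and 70%.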

Compound 3, a percentage reported as inhibition, in the whole organism at one dose (the size of the read-out at that dose, not a potency): 50%
Estimate against measurement, compound 3: 4 percentage points above; measured number inside the range.
By their numbers in this assay, from the lowest: compound 2; then compounds 3 and 1 (each within the scatter of the next).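

In this assay, methyl in place of hydrogen on the saturated chain carbon bound to a bromine atom and a carbonyl carbon gives a number 4 percentage points lower from compound 1 to compound 3 (within the scatter) and so the added methyl leaves the number within the scatter. This position thus differs from the aromatic carbon changed in compound 2, where the step went beyond the scatter. Nothing shown here bears on what lies behind this result.

As far as these compounds go, whether an ethyl group on this carbon, or an amine or chlorine in place of the bromine atom, would keep the number stays open. So does whether the methyl step would read the same alongside methoxy in place of chloro.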